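The compounds below may be only part of what the source reports. "The series", "measured", "known", "first", "only" and "open" are said of these compounds alone.

compound 1 `COc1ccc(-c2cc(/C=C/C(=O)c3ccc(OC)c(OC)c3)[nH]n2)cc1` — -49%
compound 2 `COc1ccc(C(=O)/C=C/c2cc(-c3cc(OC)c(OC)c(OC)c3)n[nH]2)cc1` — -70%
compound 3 `COc1cc(C(=O)/C=C/c2cc(-c3cc(OC)c(OC)c(OC)c3)n[nH]2)cc(OC)c1OC` — -91%

In a functional assay on OVCAR-5 cells (Homo sapiens) for cytotoxicity, read by sulforhodamine B assay, with a stated time of 48 h, tested at 10 uM (on this read-out higher numbers stand for a weaker effect at the one concentration tested and lower numbers for a stronger effect), compound 2 gives -70%, the second highest of the three numbers. Compound 1 gives -49%, a higher number, and the gap to compound 2 lies beyond the scatter. Compound 3 gives -91%, the lowest of the three, again beyond the scatter from compound 2. Compound 4 `COc1cc(-c2cc(/C=C/C(=O)c3ccc(F)c(F)c3)[nH]n2)cc(OC)c1OC` is not yet measured. Against compound 2 the change is 3,4-difluorophenyl in place of 4-methoxyphenyl on a carbonyl carbon. No step between measured compounds differing in one place is available, so the size of this change cannot be read from a shown pair; on the numbers shown only a small step is expected, if any, toward a weaker effect, within or near the scatter. Compound 4 is estimated at -62%, with a range of -92% to -32%. The expected step from compound 2 to compound 4 is a number 8 percentage points higher from compound 2 to compound 4 (within the scatter).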

Compound 4, a percentage reported as activity, at one concentration (the size of the read-out at that concentration, not a potency): 27%
Compound 4: middle estimate off by 89 percentage points, on the low side, and the stated range ends below it.
By their numbers in this assay, from the lowest: compound 3; then compound 2; then compound 1; then compound 4.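

In this assay, 3,4-difluorophenyl in place of 4-methoxyphenyl on a carbonyl carbon gives a number 97 percentage points higher from compound 2 to compound 4 (beyond the scatter) and so counts as a large step. For the compounds shown here, this is the first one-place reading of this position, which proves strongly sensitive to the change. Going by these compounds alone, compound 4 gives 27% and is the only positive number.

From the compounds shown here alone, whether the shift comes from losing the methoxy group or gaining the fluorines stays open, as does the result with an unsubstituted phenyl or a phenyl carrying an amine at this carbonyl carbon. No measurement shown explains the step.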